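Quaternary ammonium butyrates against gamma-butyrobetaine dioxygenase

The source may report more compounds than this note shows. Statements on the series, on what has been measured and on what is new or still open speak of the compounds shown alone.

Measured so far, in an assay for inhibition of gamma-butyrobetaine dioxygenase (Homo sapiens), read by HPLC, with stated times of 15 min and 30 min; a lower number here means a stronger inhibitor, a higher number a weaker inhibitor:
compound 1 `CC[N+](C)(CC)CCCC(=O)[O-]` gives 100000 nM
compound 2 `C[N+](C)(CCCC(=O)[O-])C1CCC1` gives 810 nM
compound 3 `C[N+]1(CCCC(=O)O)CCCC1` gives 490 nM

Compound 2 holds the second highest of the three numbers. Its nearest neighbour is compound 3, whose value lies within the usual scatter of compound 2, so no order between the two can be read from these numbers. Its furthest neighbour is compound 1, whose value lies far beyond the scatter, so compound 1 is clearly the weaker inhibitor of the pair. Among the compounds with values here, no pair among the three differs in a single place, so no single measured step is available as a direct guide.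

The next compound, compound 4 `CCC[N+](C)(C)CCCC(=O)[O-]`, is reached from compound 2 by the change (propyl in place of cyclobutyl on an amine nitrogen). Compound 1, carrying two ethyl groups on the nitrogen, gives the weakest number of the set, and compound 4 moves the substitution pattern on the nitrogen part of the way toward that open-chain arrangement. A step upward in this assay, beyond the scatter, is therefore expected, though smaller than the gap between compound 2 and compound 1.

For compound 4 the expected step is a 3.7-fold higher number from compound 2 to compound 4 (0.57 log units; beyond the scatter), giving an estimate of 3000 nM, with a range from 600 nM to 20000 nM.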

Compound 4, half-maximal inhibitory concentration: > 1000000 nM
Compound 4 ended at the assay's limit (the forecaster's own chance of this, stated with the estimate: 5%); middle value at least 330-fold (2.52 log units) away from the limit.
By their numbers in this assay, from the lowest: compounds 3 and 2 (each within the scatter of the next); then compound 1. At a limit, above all of these: compound 4.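

Compound 4 reads > 1000000 nM in this assay, a limit of the assay and not a number: the limit of > 1000000 nM in this assay, at which 1 of the 4 values shown sits.

Propyl in place of cyclobutyl on an amine nitrogen gives an at least 1200-fold higher number from compound 2 to compound 4 (3.09 log units; beyond the scatter), the only single-place step among the compounds shown, and it shows directly that the readout is highly sensitive to the group at this position. Because the value of compound 4 is a limit, this step gives only a lower bound on the size of the change, not its full size. The change also removes the four-membered ring and one carbon together, so this step alone cannot assign the loss to either one.

From the compounds shown here alone, a butyl group at this position would carry the same carbon count as cyclobutyl with no ring, and how it reads in this assay remains open, as does the reading for a cyclopropyl or cyclopentyl group, which would keep a ring and alter its size. Within the data shown here, also open is whether the same step holds on a longer chain to the carboxylic acid than the one shared by compound 2 and compound 4.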